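Hydroxy lactam in place of the cyclohexanone on compound 1

A few compounds are considered here, and "the series" means these few. Any claim that something is new, unique, unknown or untested is made for them only; others in the source may bear on it.

compound 1 `CC(C)c1noc(N2CCC(Oc3cc(N4CCc5cc(C6CCCCC6=O)ccc54)ncn3)CC2)n1`: 141 mL.min-1.g-1
compound 2 `CC(C)c1noc(N2CCC(Oc3cc(N4CCc5cc(N6CC(O)CCC6=O)ccc54)ncn3)CC2)n1`: 7 mL.min-1.g-1
compound 3 `CC(C)c1noc(N2CCC(Oc3cc(N4CCc5cc(N6CCCC6=O)ccc54)ncn3)CC2)n1`: 138 mL.min-1.g-1

In an ADME assay on microsomes from liver (Rattus norvegicus) for metabolic stability, read by LC-MS, using NADPH, with a stated time of 30 min, tested at 1 uM (on this read-out lower numbers stand for slow clearance and higher numbers for fast clearance), compound 1 gives 141 mL.min-1.g-1 and belongs to the upper pair of the three numbers. Its nearest neighbour is a 1.0-fold lower number from compound 1 to compound 3 (0.01 log units; within the scatter), and its furthest is a 20-fold lower number from compound 1 to compound 2 (1.30 log units; beyond the scatter).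

Compound 4 `CC(C)c1noc(N2CCC(Oc3cc(N4CCc5cc(N6CCC(O)CC6=O)ccc54)ncn3)CC2)n1` has not yet been measured. It differs from compound 1 as follows: 4-hydroxy-2-oxopiperidin-1-yl in place of 2-oxocyclohexyl on an aromatic carbon. In words, 4-hydroxy-2-oxopiperidin-1-yl stands in place of 2-oxocyclohexyl on an aromatic carbon.

Among the compounds with values here, the closest precedent is a 20-fold lower number from compound 1 to compound 2 (1.30 log units; beyond the scatter), a large step, since 5-hydroxy-2-oxopiperidin-1-yl differs from the entering group only in the number in its name. The replacement by 2-oxopyrrolidin-1-yl gives a 1.0-fold lower number from compound 1 to compound 3 (0.01 log units; within the scatter), so not every replacement of 2-oxocyclohexyl moves the number. The large 20-fold higher number from compound 2 to compound 3 (1.29 log units; beyond the scatter) sets the two replacements apart. Only compound 2 carries a hydroxy-bearing group, and the data do not show how much the other placement in compound 4 matters. A large step towards lower numbers is therefore expected, somewhat smaller than the precedent: a 12-fold lower number from compound 1 to compound 4 (1.07 log units; beyond the scatter). For compound 4 the estimated value is 12 mL.min-1.g-1, with an expected range of 4 mL.min-1.g-1 to 45 mL.min-1.g-1.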

Compound 4, intrinsic clearance in microsomes: 13 mL.min-1.g-1
Beside the measured number, compound 4's estimate is 1.1-fold (0.03 log units) below it; measured number inside the range.
By their numbers in this assay, from the lowest: compounds 2 and 4 (each within the scatter of the next); then compounds 3 and 1 (each within the scatter of the next).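

In this assay the low end of the series is no longer a single result: the 4-hydroxy-2-oxopiperidin-1-yl group also gives a large step from the ketone (an 11-fold lower number from compound 1 to compound 4 (1.04 log units; beyond the scatter)) and an equally large one from the unsubstituted five-membered lactam (an 11-fold lower number from compound 3 to compound 4 (1.03 log units; beyond the scatter)). Moving the hydroxy around the same lactam ring leaves the two hydroxy lactams inseparable (a 1.9-fold higher number from compound 2 to compound 4 (0.27 log units; within the scatter)), so among the compounds shown the low numbers do not hang on one hydroxy placement, and the four compounds fall into a low pair, compound 2 and compound 4, and a high pair, compound 1 and compound 3. No measurement at hand explains the gap between these pairs.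

The compounds shown do not separate the hydroxy from the six-membered lactam ring, as both low compounds carry the two features together and compound 3 has neither; 2-oxopiperidin-1-yl with no hydroxy would divide them. Also open, on these data alone, is whether a methoxy, an amine or a carboxylic acid on the same lactam ring would keep the number in the low pair.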